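From a Chain to a Triazole on the Shared Core

The compounds below may be only part of what the source reports. "The series", "measured", "known", "first", "only" and "open" are said of these compounds alone.

Compound 2 `COC(=O)CNC(=O)CCC(=O)Oc1ccc(C[C@H]2C(=O)OC[C@@H]2Cc2ccc(OC)c(OC)c2)cc1OC` stands lowest of the two numbers measured in an ADME assay on HeLa cells (Homo sapiens) for cytotoxicity, read by MTT assay (a higher number here means a weaker inhibitor, a lower number a stronger inhibitor), giving 179000 nM. Compound 1 `COc1ccc(C[C@H]2COC(=O)[C@@H]2Cc2ccc(OCc3cn(-c4cccc(Cl)c4)nn3)c(OC)c2)cc1OC` gives 493000 nM in this assay, a higher number beyond the scatter. Compound 3 `COc1ccc(C[C@H]2COC(=O)[C@@H]2Cc2ccc(OCc3cn(-c4ccccc4)nn3)c(OC)c2)cc1OC` has not yet been measured in this assay. It differs from compound 2 by a group of 12 heavy atoms (9 carbon, 3 nitrogen; one five-membered aromatic ring with 3 hetero atoms, one six-membered aromatic ring of carbon only) in place of a group of 12 heavy atoms (7 carbon, 1 nitrogen, 4 oxygen; no ring), on an oxygen on an aromatic ring. For the measured compounds named here, no measured pair shares this change, yet compound 3 closely resembles compound 1, whose number 493000 nM lies higher. A rise beyond the scatter is therefore expected, namely a 2.5-fold higher number from compound 2 to compound 3 (0.40 log units; beyond the scatter). Compound 3 is estimated to give about 450000 nM in this assay, between 200000 nM and 900000 nM.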

Compound 3, half-maximal inhibitory concentration: 124000 nM
Estimate against measurement, compound 3: 3.6-fold (0.56 log units) above, outside the stated range (below it).
By their numbers in this assay, from the lowest: compounds 3 and 2 (each within the scatter of the next); then compound 1.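

In this assay, (1-phenyl-1H-1,2,3-triazol-4-yl)methyl in place of the open chain on the oxygen gives a 1.4-fold lower number from compound 2 to compound 3 (0.16 log units; within the scatter) and so leaves the two groups indistinguishable at this position. Hydrogen in place of chloro on an aromatic carbon gives a 4.0-fold lower number from compound 1 to compound 3 (0.60 log units; beyond the scatter) and thus ties the higher number of compound 1 to the chloro, not to the triazole group itself. Nothing measured here gives a reason for either step. Going by these compounds, whether an amine or a fluoro on that aromatic carbon would track chloro or hydrogen remains open.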